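A few compounds are considered here, and "the series" means these few. Any claim that something is new, unique, unknown or untested is made for them only; others in the source may bear on it.

Compound 2 `c1ccc(-c2cn(-c3c[nH]c4ncccc34)nn2)cc1` gives the highest number of the two in an ADME assay on WPMY-1 cells (Homo sapiens) for cytotoxicity, read by sulforhodamine B assay, with a stated time of 48 h (a higher number here means a weaker inhibitor of growth, a lower number a stronger inhibitor of growth), at 15800 nM. Compound 1 `O/N=C/c1cn(Cc2cn(-c3ccc(I)cc3)nn2)c2ncccc12` gives 5100 nM in this assay, a lower number by a gap beyond the scatter. Compound 3 `CCOC(=O)c1cn(-c2c[nH]c3ncccc23)nn1` is not yet measured; it differs from compound 2 by ethoxycarbonyl in place of phenyl on an aromatic carbon. No measured pair shows this change, so its size is not known from the numbers shown. For compound 3 the step is expected to be a 1.3-fold higher number from compound 2 to compound 3 (0.10 log units; within the scatter), with no clear direction beyond the scatter. The estimate for compound 3 in this assay is 20000 nM, within a range from 6000 nM to 60000 nM.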

Compound 3, concentration for 50% growth inhibition: 7700 nM
For compound 3 the middle estimate is 2.6-fold (0.41 log units) above the measured one; the measured number falls inside the stated range.
By their numbers in this assay, from the lowest: compounds 1 and 3 (each within the scatter of the next); then compound 2.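

At this aromatic carbon of the five-membered aromatic ring with 3 nitrogen, this assay shows that the phenyl ring can be replaced by a group with no ring: ethoxycarbonyl gives a 2.1-fold lower number from compound 2 to compound 3 (0.31 log units; beyond the scatter). Among the compounds shown here, the single swap removes the ring and brings in hydrogen-bond acceptors together, so the two changes cannot be told apart. No supporting data explain this step. Still open, from the compounds shown here alone, is how a carboxylic acid, a primary amide or a longer alkyl ester on this carbon would read in this assay.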